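Methyl in place of chloro: an expected step

A few compounds are considered here, and "the series" means these few. Any claim that something is new, unique, unknown or untested is made for them only; others in the source may bear on it.

Compound 1 `Cc1ccc(S(=O)(=O)c2cc3cnc(Nc4cnc5c(c4)CC(=O)N5)nc3n(C)c2=O)cc1`: 15000 nM
Compound 2 `Cc1ccc(S(=O)(=O)c2cc3cnc(Nc4ccc5[nH]ccc5c4)nc3n(C)c2=O)cc1`: 750 nM
Compound 3 `Cn1c(=O)c(S(=O)(=O)c2ccc(Cl)cc2)cc2cnc(Nc3cccc4[nH]ccc34)nc21`: 5000 nM

In a functional assay on K562 cells (Homo sapiens) for inhibition, read by trypan blue exclusion, with a stated time of 72 h (a higher number here means a weaker inhibitor, a lower number a stronger inhibitor), compound 3 stands in the middle of the three, with 5000 nM. Among the measured compounds shown here, that number is lower than the one for compound 1 and higher than the one for compound 2. Compound 4 `Cc1ccc(S(=O)(=O)c2cc3cnc(Nc4cccc5[nH]ccc45)nc3n(C)c2=O)cc1` differs from compound 3 in one place: methyl in place of chloro on an aromatic carbon. In short, 4-chlorophenyl becomes 4-methylphenyl.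

For the measured compounds named here, no measured pair compares chloro with methyl directly. Going by the values given here, the only measured step, a 20-fold lower number from compound 1 to compound 2 (1.30 log units; beyond the scatter), is large, but it changes a group on a nitrogen on an aromatic ring and leaves the 4-methylphenyl alone. Compound 1 with 15000 nM and compound 2 with 750 nM both carry 4-methylphenyl, so that group does not settle the level by itself. No step beyond the scatter is therefore expected in this assay. The expected change is a 1.3-fold lower number from compound 3 to compound 4 (0.10 log units; within the scatter). Compound 4 is estimated at 4000 nM, with an expected range of 1300 nM to 12000 nM.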

Compound 4, half-maximal inhibitory concentration: 5000 nM
Beside the measured number, compound 4's estimate is 1.3-fold (0.10 log units) below it; the range from low to high includes it.
By their numbers in this assay, from the lowest: compound 2; then compounds 3 and 4 (each within the scatter of the next); then compound 1.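

In this assay, exchanging 4-chlorophenyl for 4-methylphenyl gives no change at the digits printed from compound 3 to compound 4 (within the scatter), so with the 1H-indol-4-yl group in place, chloro and methyl cannot be told apart at this position, para to a large group. With 4-methylphenyl held constant, the group on the nitrogen does separate the compounds: moving the attachment point of the indole gives a 6.7-fold higher number from compound 2 to compound 4 (0.82 log units; beyond the scatter), and the other exchange of that group gives a 3.0-fold lower number from compound 1 to compound 4 (0.48 log units; beyond the scatter). No supporting evidence bears on why these numbers fall as they do.

The compounds shown leave open whether chloro and methyl would also match when the 1H-indol-5-yl group of compound 2 is present. They also leave open how a clearly different group at this position, such as an amine, a methoxy group or a carboxylic acid, would compare.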